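The source may report more compounds than this note shows. Statements on the series, on what has been measured and on what is new or still open speak of the compounds shown alone.

Measured so far:
- compound 1 `COc1cc2c(c(OCc3ccccc3)c1OC)C(=O)[C@]1(OC)C=C[C@H]2N(C(=O)OCC(C)C)N1C(=O)OCC(C)C`: 94 ug/mL
- compound 2 `COC(=O)N1[C@@H]2C=C[C@@](OC)(C(=O)c3c2cc(OC)c(OC)c3OCc2ccc(F)cc2)N1C(=O)OC`: 56.6 ug/mL
- compound 3 `COC(=O)N1[C@@H]2C=C[C@@](OC)(C(=O)c3c2cc(OC)c(OC)c3OCc2ccccc2F)N1C(=O)OC`: 137 ug/mL

In an ADME assay on KB cells (Homo sapiens) for cytotoxicity (a higher number here means that more compound is needed for the effect, a lower number that less compound is needed), compound 1 lies within the usual scatter of both compound 2 and compound 3, so its number sits among the others without a clear rank. Compound 4 `COc1ccc(COc2c(OC)c(OC)cc3c2C(=O)[C@]2(OC)C=C[C@H]3N(C(=O)OCC(C)C)N2C(=O)OCC(C)C)cc1` is compound 1 with one change, benzyl to 4-methoxybenzyl: methoxy in place of hydrogen on an aromatic carbon. That is methoxy in place of hydrogen on an aromatic carbon.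

Among the measured compounds shown here, only one measured step touches this phenyl ring: a 2.4-fold higher number from compound 2 to compound 3 (0.38 log units; beyond the scatter). There, 2-fluorophenyl replaces 4-fluorophenyl. It moves a fluorine rather than adding a methoxy, so it is a guide to size only, and it says nothing about direction. For the measured compounds named here, no measured compound carries the methoxy. A small step in this assay is therefore expected, possibly no larger than the scatter, with its direction open. The expected step is a 1.1-fold lower number from compound 1 to compound 4 (0.04 log units; within the scatter). For compound 4 the estimated value is 85 ug/mL, with an expected range from 38 ug/mL to 190 ug/mL.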

Compound 4, concentration for half-maximal effect: 47.9 ug/mL
The estimate for compound 4 lay 1.8-fold (0.25 log units) above the measured number; measured number inside the range.
By their numbers in this assay, from the lowest: compounds 4, 2, 1 and 3 (each within the scatter of the next, the first and the last beyond it).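

Compound 1 carries a plain benzyl group and compound 4 a 4-methoxybenzyl group, so this pair reads a new group added to this phenyl ring, where the earlier step only moved a fluorine around it. In this assay the pair gives a 2.0-fold lower number from compound 1 to compound 4 (0.29 log units; within the scatter), so adding the methoxy on this aromatic carbon, para to a large group, leaves the number inside what repeated measurements of one compound would give. One step with a single group cannot set a trend, and nothing available here gives a reason for the size of this step.

Still open, going by these compounds, is how this same carbon responds to a carboxylic acid, an amine or a longer chain such as butoxy. Also open, on these data alone, is whether a methoxy at another carbon of this ring, or on the core of compound 2, would read the same.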